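Replacing a Hydroxy Hydrogen with Methyl on Compound 2

The compounds below may be only part of what the source reports. "The series", "measured", "known", "first", "only" and "open" are said of these compounds alone.

Measured so far in a functional assay (trachea) with Cavia porcellus as the target (a higher number here means that more compound is needed for the effect, a lower number that less compound is needed), for two compounds
Compound 1 `CCCn1c(=O)n(C)c(=O)c2c1ncn2CCC(=O)O` gives > 100000 nM as a limit of the assay
Compound 2 `CCCn1c(=O)n(C)c(=O)c2c1ncn2CCO` gives 31800 nM as a measured number

Within the data shown here, compound 2 holds the only actual number so far in this assay and the sole comparison is with a limit. Compound 1 stands at the limit of > 100000 nM in this assay, at which 1 of the 2 values shown sits, and that value is a limit only. Compound 3 `CCCn1c(=O)n(C)c(=O)c2c1ncn2CCOC` carries methyl in place of hydrogen on an oxygen on a saturated carbon, turning 2-hydroxyethyl into 2-methoxyethyl (methyl in place of hydrogen on an oxygen on a saturated carbon). Among the measured compounds shown here, the one measured step, an at least 3.1-fold lower number from compound 1 to compound 2 (0.49 log units; beyond the scatter), replaced carboxy with hydroxy at that chain end and so bears only loosely on this change. A small step is therefore expected in this assay, perhaps slightly lower and possibly none beyond the scatter. The estimated value for compound 3 is 25000 nM, with an expected range from 8000 nM to 80000 nM here.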

Compound 3, half-maximal effective concentration: 36100 nM
Estimate against measurement, compound 3: 1.4-fold (0.16 log units) below, and the stated range covers the measured number.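

In this assay, methyl in place of hydrogen on the oxygen of compound 2 leaves the two numbers within the scatter of each other (a 1.1-fold higher number from compound 2 to compound 3 (0.06 log units; within the scatter)), so at this chain end the hydroxy hydrogen is not required for the activity of compound 2. Methoxy, like hydroxy, also stands apart from carboxy (an at least 2.7-fold lower number from compound 1 to compound 3 (0.44 log units; beyond the scatter)). The value of compound 1 in that step is a limit: the limit of > 100000 nM in this assay, at which 1 of the 3 values shown sits. From the compounds shown here alone, it remains open whether an amine or a carboxamide at this chain end, or a longer chain, would give a lower number.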